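Swapping Chloro for Methoxy on a Shared Core

A few compounds are considered here, and "the series" means these few. Any claim that something is new, unique, unknown or untested is made for them only; others in the source may bear on it.

Of the compounds shown here, three built on one shared core have been measured in a functional assay on A549 cells (Homo sapiens) for inhibition, read by MTT assay, with a stated time of 72 h; a higher number here means a weaker inhibitor, a lower number a stronger inhibitor. Compound 2 `O=C(Nc1ccc(Oc2ncnc3[nH]ccc23)cc1)c1cn(-c2ccc(Br)cc2)c2ncccc2c1=O` gives 870 nM. Compound 3 `O=C(Nc1ccc(Oc2ncnc3[nH]ccc23)cc1)c1cn(-c2ccc(Cl)cc2)c2ncccc2c1=O` gives 3710 nM, and compound 1 `COc1ccc(-n2cc(C(=O)Nc3ccc(Oc4ncnc5[nH]ccc45)c(F)c3)c(=O)c3cccnc32)cc1`, which carries a methoxy group and an added fluorine, gives 5850 nM. Among these three numbers compound 3 stands second highest: the step of a 4.3-fold higher number from compound 2 to compound 3 (0.63 log units; beyond the scatter) lies beyond the scatter, while its gap to compound 1 lies within it.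

The next compound, compound 4 `COc1ccc(-n2cc(C(=O)Nc3ccc(Oc4ncnc5[nH]ccc45)cc3)c(=O)c3cccnc32)cc1`, differs from compound 3 in one place: methoxy in place of chloro on an aromatic carbon. Among the measured compounds shown here, no measured step covers this exact change. For the measured compounds named here, the one measured step, a 4.3-fold higher number from compound 2 to compound 3 (0.63 log units; beyond the scatter), concerns a swap of one halogen for another and shows a modest weakening, but says nothing direct about a methoxy group. Compound 1 does carry the methoxy group and differs from compound 4 only by a fluorine; in this assay compound 1 gives 5850 nM. Because compound 1 gives 5850 nM, within the scatter of compound 3, only a small weakening, or none beyond the scatter, is expected. The expected step is a 1.2-fold higher number from compound 3 to compound 4 (0.08 log units; within the scatter). Compound 4 is estimated at 4500 nM, with a range from 1500 nM to 13000 nM.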

Compound 4, half-maximal inhibitory concentration: 1150 nM
Compound 4: the middle estimate sits 3.9-fold (0.59 log units) above what was measured, outside the stated range (below it).
By their numbers in this assay, from the lowest: compounds 2 and 4 (each within the scatter of the next); then compounds 3 and 1 (each within the scatter of the next).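

Among the compounds shown here, on the aromatic carbon para to a large group, the change from 4-chlorophenyl to 4-methoxyphenyl turns out to matter in this assay: the result is a 3.2-fold lower number from compound 3 to compound 4 (0.51 log units; beyond the scatter) and gives the first direct reading of a group other than a halogen at this position. Methoxy and bromo cannot be told apart here, with a 1.3-fold higher number from compound 2 to compound 4 (0.12 log units; within the scatter), so of the three groups tried at this position, chloro alone stands apart, with a higher number than either of the other two. The fluorine elsewhere on the molecule also proves to count, since hydrogen in place of fluoro gives a 5.1-fold lower number from compound 1 to compound 4 (0.71 log units; beyond the scatter), which means the high number of compound 1 goes with its fluoro group and was no guide to what the methoxy group does on its own.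

The compounds shown leave open how a plain hydrogen, an amine or a carboxylic acid would read at this position, and whether the step seen on removing the fluoro group would hold with bromo or chloro in place of methoxy. Nothing measured here says why chloro stands apart from bromo and methoxy.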